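This account rests on a few compounds, and the source may have more. Where it says the series, first, only, none or still open, it means among the compounds named here.

Measured in an ADME assay on NCI-H460 cells (Homo sapiens) for cytotoxicity, read by MTT assay, with a stated time of 72 h; a lower number here means a stronger inhibitor, a higher number a weaker inhibitor:
- Compound 1 `COc1cccc(-n2nnc(-c3ccccc3NC(=O)c3ccc(NC(C)=O)cc3)n2)c1`: > 100000 nM (a limit of the assay, not a number)
- Compound 2 `COc1cccc(-n2nnc(-c3ccccc3NC(=O)c3ccc(N=[N+]=[N-])cc3)n2)c1`: 20300 nM
- Compound 3 `COc1ccc(NC(=O)Nc2ccccc2-c2nnn(-c3ccc(OC)cc3)n2)cc1`: 52500 nM

Of the two results that are actual numbers, compound 2 has the lower, at 20300 nM. Compound 3 gives a higher number, 52500 nM, and the gap lies beyond the usual scatter.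

The next compound to be tested is compound 4 `COc1cccc(-n2nnc(-c3ccccc3NC(=O)Nc3ccc([N+](=O)[O-])cc3)n2)c1`. Going from compound 2 to it, (4-nitrophenyl)amino replaces 4-azidophenyl on a carbonyl carbon: (4-nitrophenyl)amino in place of 4-azidophenyl on a carbonyl carbon.

Within the data shown here, only one measured step bears directly on this change, and it alters the same 4-azidophenyl group: an at least 4.9-fold lower number from compound 1 to compound 2 (0.69 log units; beyond the scatter). That shows the number can respond to a change in this part of the molecule, but it does not measure the present swap. The closer guide is compound 3 at 52500 nM, which also has an aryl amino group on the carbonyl carbon. A modest rise is therefore expected, meaning a weaker inhibitor.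

The expected step is a 2.2-fold higher number from compound 2 to compound 4 (0.35 log units; beyond the scatter). A result at the limit of > 100000 nM in this assay, at which 1 of the 3 values shown sits, also remains possible. For compound 4 the estimated value is 45000 nM, with an expected range of 15000 nM to 100000 nM.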

Compound 4, half-maximal inhibitory concentration: > 100000 nM
Compound 4 was reported as a limit (the forecaster's own chance of this, stated with the estimate: 25%); at least 2.2-fold (0.34 log units) between middle value and limit.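

In this assay compound 4 gives > 100000 nM, which is a limit of the assay and not a number. Replacing 4-azidophenyl on the carbonyl carbon with (4-nitrophenyl)amino gives an at least 4.9-fold higher number from compound 2 to compound 4 (0.69 log units; beyond the scatter), so this place in the molecule can lose the measurable effect through a second, different change, not only through the acetamido group seen earlier. Of the three compounds linked by single changes, only compound 2 therefore has a readable number, while the step between compound 1 and compound 4 cannot be read, and both belong to a wider picture: the limit of > 100000 nM in this assay, at which 2 of the 4 values shown sit.

This swap changes two things at once, adding an amino link to the carbonyl carbon and exchanging azido for nitro, so the compounds shown cannot say which of the two accounts for the step. A plain 4-nitrophenyl group on the carbonyl carbon, or (4-azidophenyl)amino, would separate the two changes, and a simple amine or a carboxylic acid in place of the nitro group would test how far the result depends on that group.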